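This account rests on a few compounds, and the source may have more. Where it says the series, first, only, none or still open, it means among the compounds named here.

Three compounds share one core and differ only in the group on the carbonyl carbon attached to the saturated six-membered ring. Compound 1 `COc1cc2nc(N3CCC(C(=O)NC4CCCC4)CC3)nc(N)c2cc1OC` gives 0.63 nM in an assay on isolated protein for displacement of a labelled ligand from Adrenergic receptor alpha-1 (Rattus norvegicus); on this read-out higher numbers stand for weaker inhibition and lower numbers for stronger inhibition. Compound 2 `COc1cc2nc(N3CCC(C(=O)N4CCOCC4)CC3)nc(N)c2cc1OC` gives 1.14 nM, and compound 3 `COc1cc2nc(N3CCC(C(=O)NCc4ccccc4)CC3)nc(N)c2cc1OC` gives 0.22 nM. Compound 3 stands lowest of the three, with compound 1 nearest (a 2.9-fold lower number from compound 1 to compound 3 (0.46 log units; beyond the scatter)) and compound 2 furthest (a 5.2-fold lower number from compound 2 to compound 3 (0.71 log units; beyond the scatter)). The step from compound 1 to compound 2 stays within the scatter (a 1.8-fold higher number from compound 1 to compound 2 (0.26 log units; within the scatter)).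

Compound 4 `CCCNC(=O)CC1CCN(c2nc(N)c3cc(OC)c(OC)cc3n2)CC1` has not been measured. Its change from compound 3 is (propylcarbamoyl)methyl in place of benzylcarbamoyl on a saturated ring carbon. Among the compounds with values here, the steps that bear on it are those into compound 3: both the cyclopentylamino and the morpholin-4-yl amide gave higher numbers than the benzylamino amide, and compound 4 now carries a chain with no ring at all. A modest rise is therefore expected, and the estimated step is a 3.2-fold higher number from compound 3 to compound 4 (0.50 log units; beyond the scatter). Compound 4 is expected to give about 0.7 nM, within a range of 0.3 nM to 1.8 nM.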

Compound 4, inhibition constant: 0.65 nM
The estimate for compound 4 lay 1.1-fold (0.03 log units) above the measured number; low and high end bracket the measured number.
By their numbers in this assay, from the lowest: compound 3; then compounds 1, 4 and 2 (each within the scatter of the next).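

Until now, every group on this saturated ring carbon held its carbonyl directly on the ring and carried a ring of its own. (Propylcarbamoyl)methyl does neither, yet in this assay it reads level with two of those amides: a 1.0-fold higher number from compound 1 to compound 4 (0.01 log units; within the scatter) and a 1.8-fold lower number from compound 2 to compound 4 (0.24 log units; within the scatter), both small enough to count as no real difference. Among the groups shown, only benzylcarbamoyl stands apart, with a 3.0-fold higher number from compound 3 to compound 4 (0.47 log units; beyond the scatter), so a ring in this group is not required to reach the range of compound 1, though no measurement here explains any of these differences.

Compound 4 alters two things at once, the chain on the amide nitrogen and the methyl link to the ring, and the compounds shown cannot separate them. Open questions are how a benzyl amide on that same methyl link, a propyl amide directly on the ring, or a longer chain would read.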